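The compounds below may be only part of what the source reports. "The series", "measured", "known", "first", "only" and "open" are said of these compounds alone.

Compound 1 `O=C(c1cccc(F)c1)N1CC(c2nc(-c3cccc(Cl)c3)no2)C1` and compound 2 `Cc1cccc(-c2noc(C3CN(C(=O)c4cccc(F)c4)C3)n2)c1` share a core and differ in one spot only: methyl in place of chloro on an aromatic carbon. In an assay on HEK293 cells for negative allosteric modulation of metabotropic glutamate receptor 5 (Homo sapiens), read by FLIPR (a lower number here means a stronger inhibitor, a higher number a weaker inhibitor), compound 1 gives 780 nM, and compound 2 gives 2100 nM. That change brought a 2.7-fold higher number from compound 1 to compound 2 (0.43 log units; beyond the scatter).

Compound 3 `Cc1cccc(-c2noc(C3CN(S(=O)(=O)c4ccc(Cl)cc4)C3)n2)c1` is built on a different core; the difference between the two cores is not broken down here. In this assay compound 3 gives 1100 nM, a number that sits within the usual scatter of both compound 1 and compound 2.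

Compound 4 `Cc1ccc(S(=O)(=O)N2CC(c3nc(-c4cccc(C)c4)no3)C2)cc1` has not yet been measured. It is made from compound 3 by the same kind of change as before: methyl in place of chloro on an aromatic carbon. The place is not quite the same, since in compound 2 the new methyl sits meta to a large group, while in compound 4 it sits para to a large group.

Setting the earlier step beside the new one, a weakening of similar size is expected, a 2.3-fold higher number from compound 3 to compound 4 (0.36 log units; beyond the scatter), resting on a 2.7-fold higher number from compound 1 to compound 2 (0.43 log units; beyond the scatter). For compound 4 the estimate in this assay is therefore 2500 nM, lying between 1100 nM and 5500 nM.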

Compound 4, half-maximal inhibitory concentration: 670 nM
For compound 4 the middle estimate is 3.7-fold (0.57 log units) above the measured one; measured number outside the range, below it.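

On the core of compound 3, methyl in place of chloro gives a 1.6-fold lower number from compound 3 to compound 4 (0.22 log units; within the scatter), so on this core the change cannot be told apart from the ordinary spread of repeated measurements. The change therefore does not carry over at one fixed size between these two cores in this assay: the same change on two cores in this assay, a 2.7-fold higher number (0.43 log units; beyond the scatter) from compound 1 to compound 2 and a 1.6-fold lower number (0.22 log units; within the scatter) from compound 3 to compound 4, 4.4-fold (0.65 log units) apart, beyond the scatter of two such steps

This does not show that the core alone sets the size of the step, since the swapped atom also sits in a different place in the two pairs, and two pairs give no rule for the whole series.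

The compounds shown leave open how the swap from 4-chlorophenyl to 4-methylphenyl would read on the core of compound 1, where it would match the place of the change in compound 4. Also open, going by these compounds, is how other groups at that place, such as a methoxy group, a nitrile or an amine, would compare with chloro and methyl.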